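Aryl change on the ring nitrogen: outlook for compound 4

This account rests on a few compounds, and the source may have more. Where it says the series, first, only, none or still open, it means among the compounds named here.

Measured so far in a functional assay on CHO cells with adenosine receptor A1 (Homo sapiens) as the target, read by cAMP accumulation and immunoassay, with a stated time of 6 min, tested at 0.01 uM; on this read-out higher numbers stand for a weaker effect at the one concentration tested and lower numbers for a stronger effect:
compound 1 `Nc1scc(CN2CCN(c3cc(Cl)cc(Cl)c3)CC2)c1C(=O)c1ccc(Cl)cc1` gives -1%
compound 2 `COc1ccc(N2CCN(Cc3csc(N)c3C(=O)c3ccc(Cl)cc3)CC2)cc1` gives -1.2%
compound 3 `Nc1scc(CN2CCN(c3cccc(C(F)(F)F)c3)CC2)c1C(=O)c1ccc(Cl)cc1` gives -8.2%

Compound 3 holds the lowest of the three numbers, but its neighbours sit close: a number 7 percentage points lower from compound 2 to compound 3 (within the scatter) and a number 7.2 percentage points lower from compound 1 to compound 3 (within the scatter) are both within the scatter, as is a number 0.2 percentage points lower from compound 1 to compound 2 (within the scatter). All three read-outs lie near zero, so the series as shown has not moved in this assay whatever aryl group sits on the amine nitrogen in the ring.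

Compound 4 `Nc1scc(CN2CCN(c3ccccc3F)CC2)c1C(=O)c1ccc(Cl)cc1` is the next variation at the same place: 2-fluorophenyl in place of 3-(trifluoromethyl)phenyl on an amine nitrogen in a ring. The three measured steps all swap the aryl group on that ring nitrogen, and none of them produced a step beyond the scatter. On that basis no step beyond the scatter is expected from compound 3 to compound 4 either, and the estimated step is a number 4.2 percentage points higher from compound 3 to compound 4 (within the scatter). For compound 4 the expected read-out in this assay is -4%, with a range of -13% to 5%, which keeps it among the near-zero numbers of compound 1, compound 2 and compound 3.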

Compound 4, a percentage reported as activity, at one concentration (the size of the read-out at that concentration, not a potency): 2.1%
For compound 4 the middle estimate is 6.1 percentage points below the measured one; measured number inside the range.
By their numbers in this assay, from the lowest: compounds 3, 2, 1 and 4 (each within the scatter of the next, the first and the last beyond it).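

In this assay, among these compounds, the exchange of 3-(trifluoromethyl)phenyl for 2-fluorophenyl on the amine nitrogen in the ring gives a number 10.3 percentage points higher from compound 3 to compound 4 (beyond the scatter) and so yields the first step at this position beyond the scatter, though a modest one. Among the compounds shown here, this separation belongs to that pair alone, since the same 2-fluorophenyl group set against 4-methoxyphenyl gives a number 3.3 percentage points higher from compound 2 to compound 4 (within the scatter) and set against 3,5-dichlorophenyl gives a number 3.1 percentage points higher from compound 1 to compound 4 (within the scatter) and these two steps leave no ordering among those compounds. The position can therefore register a small difference between two aryl groups, but all four read-outs remain near zero and nothing at hand explains why this one pair separates.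

Still open, going by these compounds, is whether the step follows the loss of the trifluoromethyl group, the presence of the fluorine or the place of either on the phenyl ring, and whether it would repeat on a second measurement, given how little it exceeds the scatter. Also open, on these data alone, is how a plain phenyl, a pyridine ring, a benzyl group or a carboxylic acid on the same ring nitrogen would read, and whether any of them would move the number clearly away from zero.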